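The compounds below may be only part of what the source reports. "The series", "measured", "known", "first", "only" and "open" are said of these compounds alone.

Series on the shared core of compound 1 `Cc1ccccc1-c1nnc(NN)s1` with variation on the amine nitrogen. In a functional assay on the whole organism with Mus musculus as the target, in the maximal electroshock model, with a stated time of 1 h (on this read-out lower numbers stand for an effect already at smaller amounts and higher numbers for an effect only at larger amounts of compound), compound 1 returns only a limit, > 100 mg/kg. Compound 2 `CNNc1nnc(-c2ccccc2C)s1` likewise returns only a limit in this assay, > 100 mg/kg. Among the compounds with values here, compound 3 `Cc1ccccc1-c1nnc(NNC(C)C)s1` is the one member with a number, giving 83 mg/kg in this assay. The two remaining values are the limit of > 100 mg/kg in this assay, at which 2 of the 3 values shown sit. Compound 4 `Cc1ccccc1-c1nnc(NNC2CCCC2)s1` is not yet measured; it differs from compound 3 by cyclopentyl in place of isopropyl on an amine nitrogen. The steps that reach compound 3 bear on this change: an at least 1.2-fold lower number from compound 1 to compound 3 (0.08 log units; that floor lies within the scatter) and an at least 1.2-fold lower number from compound 2 to compound 3 (0.08 log units; that floor lies within the scatter), while there is a step that the two limits leave unreadable from compound 1 to compound 2. Enlarging the alkyl on this nitrogen has so far given no step readable beyond the scatter, so for compound 4 no step beyond the scatter is expected, a 1.3-fold lower number from compound 3 to compound 4 (0.11 log units; within the scatter). Compound 4 is therefore estimated at 65 mg/kg, with a range from 25 mg/kg to 160 mg/kg.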

Compound 4, dose for half-maximal effect: > 100 mg/kg
Compound 4: only a limit was reported; the forecaster's own chance of this, stated with the estimate: 35%; middle value at least 1.5-fold (0.18 log units) from the limit.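

In this assay compound 4 gives > 100 mg/kg, which is a limit and not a number. Cyclopentyl in place of isopropyl on the amine nitrogen gives an at least 1.2-fold higher number from compound 3 to compound 4 (0.08 log units; that floor lies within the scatter), so this larger group with a ring yields no readable separation, and the steps to compound 4 from compound 1 and compound 2 join two limits and cannot be read. Compound 3 remains the only member of the series with a number: the limit of > 100 mg/kg in this assay, at which 3 of the 4 values shown sit.

Open, on these data alone, is whether a longer open chain, a phenyl or a hydroxyethyl on this nitrogen would give a step beyond the scatter. Also open, as far as these compounds go, is how far compound 4 actually lies from compound 3.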